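The compounds below may be only part of what the source reports. "The series", "measured", "known", "first", "only" and "open" are said of these compounds alone.

Compounds measured so far:
compound 1, `CCC(=O)N(Cc1ccc(OC)c(O)c1)c1cc(OC)c(OC)c(OC)c1` — in a functional assay on HCT-116 cells (Homo sapiens) for inhibition, read by MTT assay, with a stated time of 48 h (a higher number here means a weaker inhibitor, a lower number a stronger inhibitor), compound 1 gives 61 nM
compound 2, `COc1cc(NCc2cccc(O)c2)cc(OC)c1OC` — in this assay compound 2 gives 67700 nM

Of these two numbers, compound 1 has the lower one, and the gap to compound 2 is far outside the usual scatter, so compound 1 is the stronger inhibitor of the pair in this assay. Among the measured compounds shown here, compound 2 shares the core of compound 1 but lacks both the amide and the methoxy group on the benzyl ring, so no single-point step between them can be read.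

Compound 3, `COc1ccc(CN(C(=O)C=C(C)C)c2cc(OC)c(OC)c(OC)c2)cc1O`, is the next compound to be measured in this assay. It differs from compound 1 in one place:

2-methylprop-1-en-1-yl in place of ethyl on a carbonyl carbon

The amide is kept and only the group on its carbonyl carbon grows by two carbons and gains a double bond. For the measured compounds named here, nothing among the measured compounds tests this position, so no step is known here. A small step is expected, if any at all: the estimated step of a 1.3-fold higher number from compound 1 to compound 3 (0.12 log units; within the scatter) is not expected to go beyond the scatter. For compound 3 the estimate in this assay is 80 nM, with a range from 25 nM to 260 nM.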

Compound 3, half-maximal inhibitory concentration: 290 nM
Compound 3: middle estimate off by 3.6-fold (0.56 log units), on the low side; measured number above the stated range.
By their numbers in this assay, from the lowest: compound 1; then compound 3; then compound 2.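

The group on the carbonyl carbon of the amide proves to matter in this assay: putting 2-methylprop-1-en-1-yl in place of ethyl gives a 4.8-fold higher number from compound 1 to compound 3 (0.68 log units; beyond the scatter), a modest step but one beyond the scatter. Among the compounds shown here, this is the first reading at this position, and it shows that the amide alone does not fix the number, since the group it carries also shifts it, here towards a weaker inhibitor. Nothing available explains this step.

The change brings more carbons and a double bond together, so the compounds shown cannot say which of the two goes with the higher number. A saturated 2-methylpropyl group on the same carbonyl carbon would separate them, while a methyl group would show whether going shorter than ethyl moves the number the other way.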